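The source may report more compounds than this note shows. Statements on the series, on what has been measured and on what is new or still open speak of the compounds shown alone.

Measured compounds:
Compound 1 `FC(F)(F)c1c(CN2CCC(c3ccccc3)CC2)ccn2c(CC3CC3)nnc12` gives 21 nM.
Compound 2 `FC(F)(F)c1c(CN2CCCC(c3ccccc3)C2)ccn2c(CC3CC3)nnc12` gives 65 nM.

These two values come from an assay on CHO cells for positive allosteric modulation of metabotropic glutamate receptor 2 (Homo sapiens), read by scintillation counting, with a stated time of 30 min; a higher number here means that more compound is needed for the effect, a lower number that less compound is needed. Within the data shown here, compound 2 carries the higher of the two numbers, and the gap between compound 2 and compound 1 lies beyond the usual scatter; no single-point step between them is drawn here, so only the two values themselves are compared.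

Compound 3 `CC1(c2ccccc2)CCCN(Cc2ccn3c(CC4CC4)nnc3c2C(F)(F)F)C1` has not yet been measured in this assay. Its difference from compound 2 is methyl in place of hydrogen on a saturated ring carbon, the carbon that already bears the phenyl group. Among the measured compounds shown here, with no measured step of this kind available, the expectation is a change of modest size, if any, with a mild lean toward a higher number; the step from compound 2 to compound 3 is estimated at a 1.4-fold higher number from compound 2 to compound 3 (0.14 log units; within the scatter), which is expected to lie near the edge of the scatter. Compound 3 is therefore expected to give about 90 nM, with a range from 30 nM to 300 nM.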

Compound 3, half-maximal effective concentration: 2.6 nM
Compound 3: the middle estimate sits 35-fold (1.54 log units) above what was measured, outside the stated range (below it).
By their numbers in this assay, from the lowest: compound 3; then compound 1; then compound 2.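

In this assay, placing a methyl in place of hydrogen on this saturated ring carbon of the six-membered non-aromatic ring with 1 nitrogen gives a 25-fold lower number from compound 2 to compound 3 (1.40 log units; beyond the scatter), a large change beyond the scatter. The earlier compounds shown here carried only hydrogen at this position, so they could not show that the number responds so strongly here, and to an addition of just 1 heavy atom, a carbon with no hydrogen-bond donors or acceptors. Nothing available explains why a change this small has an effect of this size.

The compounds shown leave open whether the effect is particular to methyl or would also appear with an ethyl group, a hydroxyl group or a fluorine atom on the same carbon. They also leave open whether the same methyl would have a similar effect in the piperidine-free setting of a different ring size, such as a five-membered ring.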